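This account rests on a few compounds, and the source may have more. Where it says the series, first, only, none or still open, it means among the compounds named here.

In a functional assay on PC-3 cells (Homo sapiens) for antiproliferative activity, read by MTT assay, with a stated time of 48 h (on this read-out lower numbers stand for stronger inhibition of growth and higher numbers for weaker inhibition of growth), compound 1 `COc1cc(/C=C2\Cc3c(cc(OC)c(OC)c3OC)C2=O)cc(OC)c1OC` gives 4990 nM. Compound 2 `COc1cc2c(cc1O)C(=O)/C(=C/c1cc(OC)c(OC)c(OC)c1)C2` gives > 10000 nM, which is a limit of the assay and not a number. Compound 3 `COc1cc2c(cc1OC)C(=O)/C(=C/c1cc(OC)c(OC)c(OC)c1)C2` differs from compound 2 by methyl in place of hydrogen on an oxygen on an aromatic ring, or hydroxy to methoxy. Compound 1, which carries no hydroxy group, gives a measured 4990 nM, and this is the only basis for expecting some gain in this assay. The expected at least 1.2-fold lower number from compound 2 to compound 3 (0.09 log units; that floor lies within the scatter) is modest and towards stronger inhibition of growth. The estimate for compound 3 is 8000 nM, with an expected range of 3000 nM to 20000 nM.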

Compound 3, concentration for 50% growth inhibition: > 10000 nM
Compound 3 was reported as a limit; the forecaster's own chance of this, stated with the estimate: 40%; middle value at least 1.2-fold (0.09 log units) away from the limit.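

Methylating this oxygen brings no measurable activity: in this assay compound 3 gives > 10000 nM, which is a limit of the assay and not a number. Within the data shown here, the step between compound 2 and compound 3 cannot be read, because both compounds sit at the same limit: the limit of > 10000 nM in this assay, at which 2 of the 3 values shown sit. The one readable comparison, with hydrogen in place of methoxy on an aromatic carbon, gives an at least 2.0-fold higher number from compound 1 to compound 3 (0.30 log units; that floor lies within the scatter) and so adds only a weak hint that this methoxy matters. From the compounds shown here alone, whether a longer chain or an amine on this oxygen would give a measurable number in this assay remains open.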